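The compounds below may be only part of what the source reports. "The series", "measured", "known", "first", "only" and "open" are said of these compounds alone.

Compound 3 `COc1ccc(/C=N/NC(=O)Nc2ccc(Oc3ccnc(-c4nncn4CCN(C)C)c3)c(F)c2)c(OC)c1` gives 12600 nM in a functional assay on U-87MG ATCC cells (Homo sapiens) for cytotoxicity, read by MTT assay, with a stated time of 72 h (a higher number here means a weaker inhibitor, a lower number a stronger inhibitor), the highest of the three numbers recorded. Compound 2 `CN(C)CCn1cnnc1-c1cc(Oc2ccc(NC(=O)N/N=C/c3ccc(O)c(Br)c3)cc2F)ccn1` gives 12400 nM, and the step of a 1.0-fold higher number from compound 2 to compound 3 (0.01 log units; within the scatter) lies within the scatter, so the two are not told apart. Compound 1 `CN(C)CCn1cnnc1-c1cc(Oc2ccc(NC(=O)N/N=C/c3ccc(F)cc3Cl)cc2F)ccn1` gives 1210 nM, and the steps of a 10-fold higher number from compound 1 to compound 2 (1.01 log units; beyond the scatter) and a 10-fold higher number from compound 1 to compound 3 (1.02 log units; beyond the scatter) are both large. Compound 4 `COc1ccc(/C=N/NC(=O)Nc2ccc(Oc3ccnc(-c4nncn4CCN(C)C)c3)c(F)c2)c(OC)c1OC` differs from compound 3 by methoxy in place of hydrogen on an aromatic carbon. Going by the values given here, none of the measured steps adds a methoxy to an otherwise unchanged phenyl; all three swap the whole aryl. The expected step is therefore small, a 1.1-fold lower number from compound 3 to compound 4 (0.02 log units; within the scatter), without a firm direction. The estimate for compound 4 in this assay is 12000 nM, within 4500 nM to 32000 nM.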

Compound 4, half-maximal inhibitory concentration: 7650 nM
Estimate against measurement, compound 4: 1.6-fold (0.20 log units) above; the range from low to high includes it.
By their numbers in this assay, from the lowest: compound 1; then compounds 4, 2 and 3 (each within the scatter of the next).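

In this assay, the added methoxy on an otherwise unchanged phenyl does not separate the 2,3,4-trimethoxyphenyl of compound 4 from the 2,4-dimethoxyphenyl of compound 3 (a 1.6-fold lower number from compound 3 to compound 4 (0.22 log units; within the scatter)). Compound 4 is also not told apart from the 3-bromo-4-hydroxyphenyl compound (a 1.6-fold lower number from compound 2 to compound 4 (0.21 log units; within the scatter)), while the 2-chloro-4-fluorophenyl compound remains the stronger inhibitor (a 6.3-fold higher number from compound 1 to compound 4 (0.80 log units; beyond the scatter)). No measurement shown here accounts for these steps. Still open, on these data alone, is whether a hydroxyl, an amine or a fluorine at this position would differ from compound 3, and what the same methoxy would do on the aryl of compound 1.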